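Nitro to Fluoro on the Shared Core

A few compounds are considered here, and "the series" means these few. Any claim that something is new, unique, unknown or untested is made for them only; others in the source may bear on it.

compound 1, `O=[N+]([O-])c1cc(Nc2nc3nonc3nc2O)ccc1OC(F)(F)F`: 53500 nM
compound 2, `Oc1nc2nonc2nc1Nc1ccc(OC(F)(F)C(F)F)cc1`: 7000 nM

Of the compounds shown here, two have been measured in an assay on mitochondria from L6 cells (Rattus norvegicus) for activation, with a stated time of 90 min; a higher number here means that more compound is needed for the effect, a lower number that less compound is needed. Compound 1 gives 53500 nM, while compound 2 gives 7000 nM, so compound 1 stands highest of the two and the gap to compound 2 lies beyond the scatter. Compound 3 `Oc1nc2nonc2nc1Nc1ccc(OC(F)(F)F)c(F)c1` has not yet been measured. It differs from compound 1 in one place: fluoro in place of nitro on an aromatic carbon. Going by the values given here, no measured pair shows this change directly, yet compound 2, which carries no nitro group, gives the lower number, so a move toward a lower number in this assay is expected, of moderate size. Compound 3 is expected to give about 12000 nM, within 4000 nM to 40000 nM. The expected step is a 4.5-fold lower number from compound 1 to compound 3 (0.65 log units; beyond the scatter).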

Compound 3, half-maximal effective concentration: 2900 nM
Compound 3: the middle estimate sits 4.1-fold (0.62 log units) above what was measured, outside the stated range (below it).
By their numbers in this assay, from the lowest: compound 3; then compound 2; then compound 1.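

In this assay, fluoro in place of nitro on the aromatic carbon ortho to a trifluoromethoxy group gives an 18-fold lower number from compound 1 to compound 3 (1.27 log units; beyond the scatter) and so shows that this position responds strongly to what it carries. Going by these compounds alone, compound 2 differs from compound 1 in more than one place, so this pair gives the first direct reading of the change. Nothing measured here explains the size of the step. On these data alone, how an amine or a methoxy group at this position would compare remains open. So does whether the step holds with another group in place of trifluoromethoxy.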